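A few compounds are considered here, and "the series" means these few. Any claim that something is new, unique, unknown or untested is made for them only; others in the source may bear on it.

For the measured compounds named here, in an ADME assay on MT4 cells (Homo sapiens) for cytotoxicity, read by MTT assay (on this read-out lower numbers stand for higher toxicity in this test and higher numbers for lower toxicity in this test), compound 3 (`CC1C(=O)N(O)C(=O)c2ccccc21`) gives 250000 nM, the highest of the three numbers measured so far. Compound 2 (`CCCCC1C(=O)N(O)C(=O)c2ccccc21`) gives 25400 nM, and compound 1 (`CCCCCCC1C(=O)N(O)C(=O)c2ccccc21`) gives 4400 nM. The next compound, compound 4 (`CCCCCC1C(=O)N(O)C(=O)c2ccccc21`), differs from compound 3 as follows: butyl in place of hydrogen on a saturated chain carbon bound to a saturated ring carbon.

Going by the values given here, three measured steps bear on this change. Compound 2 carries propyl where compound 3 has hydrogen at that chain carbon, and the modest step is a 9.8-fold higher number from compound 2 to compound 3 (0.99 log units; beyond the scatter). Compound 1 carries pentyl there, and the large step is a 57-fold higher number from compound 1 to compound 3 (1.75 log units; beyond the scatter). The modest step of a 5.8-fold higher number from compound 1 to compound 2 (0.76 log units; beyond the scatter) separates those two compounds. Among these three compounds the number falls as the chain grows, and none goes against this.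

Since butyl lies between propyl and pentyl, a step between those two sizes is expected in this assay, towards a lower number than that of compound 3, and well beyond the scatter. The expected change is a 24-fold lower number from compound 3 to compound 4 (1.38 log units; beyond the scatter). Compound 4 is estimated at 10500 nM, with an expected range of 5500 nM to 20000 nM.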

Compound 4, half-maximal cytotoxic concentration: 98300 nM
The estimate for compound 4 lay 9.4-fold (0.97 log units) below the measured number; measured number above the stated range.
By their numbers in this assay, from the lowest: compound 1; then compound 2; then compound 4; then compound 3.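

In this assay, for the compounds shown here, the new compound breaks the steady fall with chain growth seen among the earlier compounds: going from methyl to pentyl at this saturated chain carbon bound to a saturated ring carbon gives only a 2.5-fold lower number from compound 3 to compound 4 (0.41 log units; beyond the scatter) and leaves compound 4 well above the compound with the shorter chain. The comparison with that shorter chain reads a 3.9-fold higher number from compound 2 to compound 4 (0.59 log units; beyond the scatter), so compound 4 goes against the pattern, since here a longer chain comes with a higher number rather than a lower one. The comparison with the longer chain reads a 22-fold higher number from compound 1 to compound 4 (1.35 log units; beyond the scatter), which shows that the number at this position can shift sharply with one small extension of the chain, and that the link between chain length and toxicity in this test is uneven rather than smooth across the four compounds.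

The compounds shown leave open whether the number keeps falling with a still longer chain, and how a branched chain, an amine or a carboxylic acid at this place would read. Nothing measured here offers any account of why the values follow this uneven course.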